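Fluoro to Methoxymethoxy: a Single Aromatic Substituent Swap

A few compounds are considered here, and "the series" means these few. Any claim that something is new, unique, unknown or untested is made for them only; others in the source may bear on it.

Of the compounds shown here, three built on one shared core have been tested in a toxicity assay on WI-38 cells (Homo sapiens) for cytotoxicity, read by MTT assay, with a stated time of 48 h; on this read-out higher numbers stand for weaker inhibition and lower numbers for stronger inhibition. Compound 1 `O=C(/C=C/c1ccc2c(c1)B(O)OC2)c1ccc(F)cc1` gives 7600 nM. Compound 3 `O=C(/C=C/c1ccc2c(c1)B(O)OC2)c1cccc(F)c1` gives 26700 nM, the highest of the two plain numbers. For compound 2 `O=C(/C=C/c1ccc2c(c1)B(O)OC2)c1ccc(I)cc1` this assay reports only a limit, > 100000 nM. The measured steps were a 3.5-fold higher number from compound 1 to compound 3 (0.55 log units; beyond the scatter), an at least 13-fold higher number from compound 1 to compound 2 (1.11 log units; beyond the scatter) and an at least 3.7-fold lower number from compound 2 to compound 3 (0.57 log units; beyond the scatter). Compound 4 `COCOc1cccc(C(=O)/C=C/c2ccc3c(c2)B(O)OC3)c1` differs from compound 3 by methoxymethoxy in place of fluoro on an aromatic carbon. Each earlier change to the substituent on this ring moved the number upward beyond the scatter, so for compound 4 a modest further rise is expected, a 1.7-fold higher number from compound 3 to compound 4 (0.23 log units; within the scatter). The estimated value for compound 4 in this assay is 45000 nM, within 12000 nM to 150000 nM.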

Compound 4, half-maximal inhibitory concentration: 33200 nM
For compound 4 the middle estimate is 1.4-fold (0.13 log units) above the measured one; the range from low to high includes it.
By their numbers in this assay, from the lowest: compound 1; then compounds 3 and 4 (each within the scatter of the next). At a limit, above all of these: compound 2.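

In this assay, putting methoxymethoxy in place of fluoro on this aromatic carbon gives a 1.2-fold higher number from compound 3 to compound 4 (0.09 log units; within the scatter). Unlike the earlier steps among compounds 1, 2 and 3, this change leaves two compounds that cannot be told apart, even though the entering group has more heavy atoms and hydrogen-bond acceptors than the one it replaces. Nothing measured here accounts for this result. Still open, from the compounds shown here alone, is whether an amine or a carboxylic acid at this position would also stay within the scatter of compound 3, and whether methoxymethoxy would do the same on the ring carbon carrying fluoro in compound 1.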